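This account rests on a few compounds, and the source may have more. Where it says the series, first, only, none or still open, it means among the compounds named here.

Three compounds share one core and differ only in the group on the aromatic nitrogen: compound 1 `CCNC(=O)Nc1nc2cc(-c3cccnc3)c(=O)n(CC)c2s1`, compound 2 `CCNC(=O)Nc1nc2cc(-c3cccnc3)c(=O)n(CC3CC3)c2s1` and compound 3 `CCNC(=O)Nc1nc2cc(-c3cccnc3)c(=O)n(CC3CCCCC3)c2s1`. In an ADME assay on a cell-free system (plasma, Homo sapiens) (on this read-out higher numbers stand for a larger free fraction and lower numbers for a smaller free fraction), compound 1 gives 0.11, compound 2 gives 0.05 and compound 3 gives 0.02, the lowest number of the three. Cyclopropyl in place of methyl on a saturated chain carbon bound to an aromatic nitrogen gives a 2.2-fold lower number from compound 1 to compound 2 (0.34 log units; beyond the scatter). Cyclohexyl in place of cyclopropyl gives a 2.5-fold lower number from compound 2 to compound 3 (0.40 log units; beyond the scatter), and cyclohexyl in place of methyl gives a 5.5-fold lower number from compound 1 to compound 3 (0.74 log units; beyond the scatter). All three steps are modest but beyond the scatter.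

The next compound, compound 4 `CCNC(=O)Nc1nc2cc(-c3cccnc3)c(=O)n(C(C)C(=O)O)c2s1`, has not yet been measured. It carries 1-carboxyethyl in place of cyclohexylmethyl on an aromatic nitrogen. The carbon ring leaves, as it would in reversing a 5.5-fold lower number from compound 1 to compound 3 (0.74 log units; beyond the scatter), so that largest measured step is the closest guide, and it suggests a move of similar size in the opposite direction. Within the data shown here, no measured compound carries a carboxy group, however, so this guide is only partial and the range must stay wide. In this assay the expected move is a 6.0-fold higher number from compound 3 to compound 4 (0.78 log units; beyond the scatter). For compound 4 the estimated value is 0.12, with an expected range from 0.04 to 0.35.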

Compound 4, unbound fraction: 0.22
The estimate for compound 4 lay 1.8-fold (0.26 log units) below the measured number; measured number inside the range.
By their numbers in this assay, from the lowest: compound 3; then compound 2; then compounds 1 and 4 (each within the scatter of the next).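

Among the earlier compounds, the number in this assay only fell as the carbon group on the aromatic nitrogen grew, but 1-carboxyethyl, the first group here with oxygen atoms, reverses that fall, with an 11-fold higher number from compound 3 to compound 4 (1.04 log units; beyond the scatter), the only large step in the set, and a 4.4-fold higher number from compound 2 to compound 4 (0.64 log units; beyond the scatter). The direct comparison is with the ethyl group of compound 1: adding carboxy to that chain gives a 2.0-fold higher number from compound 1 to compound 4 (0.30 log units; within the scatter), so this single change cannot be told apart from no change, and the large rise from the cyclohexylmethyl compound ends at a level the plain ethyl compound already reaches. No measurement is available that would explain any of these steps.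

The compounds shown leave open whether an amine or a simple alcohol on the same short chain would give a similar number, and whether a methyl ester would differ from the carboxylic acid. They also leave open what a carboxy group would do on a longer chain or on a cyclohexylmethyl group, where the carbon ring stays in place.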